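Adding a Second Methoxy Group to Compound 1

The source may report more compounds than this note shows. Statements on the series, on what has been measured and on what is new or still open speak of the compounds shown alone.

Within the data shown here, in a functional assay on A549 cells (Homo sapiens) for antiproliferative activity, read by sulforhodamine B assay, with a stated time of 48 h (a higher number here means a weaker inhibitor, a lower number a stronger inhibitor), compound 1 `COc1ccc(C(=O)/C=C/c2ccccc2-c2ccc(F)cc2)cc1` gives 8200 nM and holds the only true number so far. Compound 2 `COc1ccc(C(=O)/C=C/c2ccccc2-c2ccc(F)nc2)cc1` reports > 50000 nM in this assay, which is a limit of the assay and not a number. Among the measured compounds shown here, the single measured step is an at least 6.0-fold higher number from compound 1 to compound 2 (0.78 log units; beyond the scatter) and comes from 6-fluoropyridin-3-yl in place of 4-fluorophenyl on an aromatic carbon.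

Compound 3 `COc1ccc(C(=O)/C=C/c2ccccc2-c2ccc(F)cc2)cc1OC` is changed elsewhere on the core of compound 1. Its difference is methoxy in place of hydrogen on an aromatic carbon and amounts to methoxy in place of hydrogen on an aromatic carbon, ortho to a methoxy group and meta to a large group. For the measured compounds named here, no measured step covers this change. The step of an at least 6.0-fold higher number from compound 1 to compound 2 (0.78 log units; beyond the scatter) is large but concerns another part of the structure, so it offers little guidance here and only serves as a caution that a single replacement can matter. No shift beyond the scatter is therefore expected in this assay, and the estimate stays anchored on compound 1 at 8200 nM as its starting point. The expected change is a 1.3-fold lower number from compound 1 to compound 3 (0.10 log units; within the scatter) in this estimate. For compound 3 the estimated value is 6500 nM with an expected range from 1800 nM to 25000 nM as its span.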

Compound 3, half-maximal inhibitory concentration: 7500 nM
For compound 3 the middle estimate is 1.2-fold (0.06 log units) below the measured one; low and high end bracket the measured number.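

In this assay, placing a methoxy group on the carbon-only aromatic ring changes little: the result is a 1.1-fold lower number from compound 1 to compound 3 (0.04 log units; within the scatter) and gives no sign that compound 3 differs from compound 1 in this read-out. Among these compounds, this is the first reading at this position, ortho to a methoxy group and meta to a large group, since the only earlier step concerned another part of the structure; here, methoxy in place of hydrogen is tolerated without a shift beyond the scatter on the core of compound 1. Nothing shown bears on why this replacement leaves the result within the scatter.

The compounds shown leave open whether other groups at this position, such as an amine, a carboxylic acid or a longer chain like ethoxy, would also stay within the scatter. On these data alone, it also remains open whether the added methoxy group would behave the same way alongside 6-fluoropyridin-3-yl, the group carried by compound 2, for which only a limit of the assay is available.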